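Swapping methyl for methoxy on the benzyl ring

The compounds below may be only part of what the source reports. "The series", "measured", "known", "first", "only" and "open" are said of these compounds alone.

Compound 1, `Cc1ccc(Cn2cc(CSC(=S)N3CCN(C(N)=O)CC3)nn2)cc1`: in a functional assay on EC9706 cells (Homo sapiens) for cytotoxicity, read by MTT assay, with a stated time of 72 h (a lower number here means a stronger inhibitor, a higher number a weaker inhibitor), compound 1 gives > 128000 nM, which is a limit of the assay rather than a number.
Compound 2, `CCNC(=O)N1CCN(C(=S)SCc2cn(Cc3ccc(C)cc3)nn2)CC1`: compound 2 gives > 128000 nM, again a limit and not a number.
Compound 3, `CCN(C)C(=O)N1CCN(C(=S)SCc2cn(Cc3ccc(C)cc3)nn2)CC1`: compound 3 gives 70600 nM.

For the measured compounds named here, compound 3 therefore holds the only real number in the set; the rest of the picture is set by the limit of > 128000 nM in this assay, at which 2 of the 3 values shown sit. The two steps that lead to compound 3 both change the urea end of the shared core. From compound 1 to compound 3 the change is ethyl(methyl)amino in place of amino on a carbonyl carbon, giving an at least 1.8-fold lower number from compound 1 to compound 3 (0.25 log units; that floor lies within the scatter). From compound 2 to compound 3 it is methyl in place of hydrogen on an amide-type nitrogen, giving an at least 1.8-fold lower number from compound 2 to compound 3 (0.25 log units; that floor lies within the scatter). Both floors lie within the scatter, so compound 3 stands only loosely apart from the other two.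

Compound 4, `CCN(C)C(=O)N1CCN(C(=S)SCc2cn(Cc3ccc(OC)cc3)nn2)CC1`, differs from compound 3 in a different place altogether: methoxy in place of methyl on an aromatic carbon. Going by the values given here, none of the measured steps touches that aromatic ring, so no step here speaks to this change, and the expected step is none beyond the scatter, a 1.0-fold lower number from compound 3 to compound 4 (0.00 log units; within the scatter). Compound 4 is thus estimated to give about 70000 nM, somewhere between 30000 nM and 140000 nM.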

Compound 4, half-maximal inhibitory concentration: > 128000 nM
Compound 4 was reported as a limit; the forecaster's own chance of this, stated with the estimate: 30%; middle value at least 1.8-fold (0.26 log units) from the limit.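

For the compounds shown here, until now every step touched the urea end of the shared core, so this is the first reading of a change on the benzyl ring, here 4-methylbenzyl to 4-methoxybenzyl. In this assay, methoxy in place of methyl on this aromatic carbon gives an at least 1.8-fold higher number from compound 3 to compound 4 (0.25 log units; that floor lies within the scatter), so the change brings no measurable gain, though the floor alone does not establish a real loss either. With this result, compound 3 remains the only compound with an actual number, and the series gives little to compare against: the limit of > 128000 nM in this assay, at which 3 of the 4 values shown sit.

The compounds shown leave open how a chlorine atom or a hydroxyl group at this same place on the ring would read, and how far the true step here lies beyond its floor. They also leave open whether methoxy in place of methyl would read the same way on a different urea end, such as the plain amino group of compound 1.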